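Ester group variation at the oxygen next to a carbonyl

The compounds below may be only part of what the source reports. "The series", "measured", "known", "first", "only" and "open" are said of these compounds alone.

Measured so far:
compound 1 `CC(C)c1cccc(C(C)C)c1OC(=O)NC(=O)OCc1ccccc1`: 77 nM
compound 2 `CCCCCCCC(C)OC(=O)NC(=O)Oc1c(C(C)C)cccc1C(C)C`: 97 nM

Both compounds share the same core and differ only in the group on an oxygen next to a carbonyl group. In an assay on microsomes from intestine for inhibition of acyl-CoA:cholesterol acyltransferase (Oryctolagus cuniculus) (on this read-out lower numbers stand for stronger inhibition and higher numbers for weaker inhibition), compound 1 gives 77 nM and compound 2 gives 97 nM; the step of a 1.3-fold higher number from compound 1 to compound 2 (0.10 log units; within the scatter) is within the scatter. Among the measured compounds shown here, on the numbers so far compound 2 carries the highest value, compound 1 being nearest, but the gap between them does not separate the two.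

Compound 3 `CCCCC(C)(C)OC(=O)NC(=O)Oc1c(C(C)C)cccc1C(C)C` is the next member. It differs from compound 2 in one place: a group of 7 heavy atoms (7 carbon; no ring) in place of a group of 9 heavy atoms (9 carbon; no ring), on an oxygen next to a carbonyl group. The group that leaves has no common name; the group that enters is 1,1-dimethylpentyl.

For the measured compounds named here, only one measured step bears on this change, a 1.3-fold higher number from compound 1 to compound 2 (0.10 log units; within the scatter), and it shows that exchanging a ring-bearing group for a chain on this oxygen left this assay unmoved beyond the scatter. A further exchange of one chain for a shorter, more branched chain therefore gives no ground to expect a step beyond the scatter in either direction. Compound 3 is expected to give 110 nM in this assay, within 50 nM to 250 nM, corresponding to an expected step of a 1.1-fold higher number from compound 2 to compound 3 (0.05 log units; within the scatter).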

Compound 3, half-maximal inhibitory concentration: 64 nM
Estimate against measurement, compound 3: 1.7-fold (0.24 log units) above; low and high end bracket the measured number.
By their numbers in this assay, from the lowest: compounds 3, 1 and 2 (each within the scatter of the next).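

Notes on the ester group: in this assay a chain of 7 heavy atoms, 1,1-dimethylpentyl, in place of a chain of 9 heavy atoms on an oxygen next to a carbonyl group gives a 1.5-fold lower number from compound 2 to compound 3 (0.18 log units; within the scatter), so this second exchange, between two chains without a ring, also stays inside the scatter. 1,1-dimethylpentyl in place of benzyl gives a 1.2-fold lower number from compound 1 to compound 3 (0.08 log units; within the scatter), which adds a direct comparison of this chain with the ring-bearing group and likewise does not separate them, so compound 1, compound 2 and compound 3 now form a set in which no pair is resolved at this position. No measurement available here accounts for this flat result.

The three groups shown are all built from carbon and hydrogen only, so it remains open whether an amine or a carboxylic acid at the end of the chain would move the number beyond the scatter. Also open is how far the flat range extends, both towards a short group such as methyl and towards a longer chain than any shown here.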